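This account rests on a few compounds, and the source may have more. Where it says the series, first, only, none or still open, it means among the compounds named here.

Measured compounds:
- compound 1 `C[C@@]1(O)[C@H](O)[C@@H](CO)O[C@H]1n1cnc2c(ONC(=O)OCc3ccccc3)nc(N)nc21`: in an ADME assay on PBMC cells (Homo sapiens) for cytotoxicity, read by trypan blue exclusion, with a stated time of 6 days (on this read-out lower numbers stand for higher toxicity in this test and higher numbers for lower toxicity in this test), compound 1 gives 88000 nM.
- compound 2 `CONc1nc(N)nc2c1ncn2[C@@H]1O[C@H](CO)[C@@H](O)[C@@]1(C)O`: in this assay compound 2 reaches only the limit > 100000 nM.
- compound 3 `C[C@@]1(O)[C@H](O)[C@@H](CO)O[C@H]1n1cnc2c(NO)nc(N)nc21`: in this assay compound 3 likewise reaches only the limit > 100000 nM.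

Compound 3 stands at the limit of this assay; its value is a limit, not a number, and one further value sits there too (the limit of > 100000 nM in this assay, at which 2 of the 3 values shown sit). The step that the two limits leave unreadable from compound 2 to compound 3 therefore has no readable size. Compound 4 `C=C(OCC)c1nc(N)nc2c1ncn2[C@@H]1O[C@H](CO)[C@@H](O)[C@@]1(C)O` differs from compound 3 by 1-ethoxyethenyl in place of hydroxyamino on an aromatic carbon. Among the measured compounds shown here, no measured step bears directly on this change. Because compound 3 sits at the limit > 100000 nM, compound 4 is expected to stay near that limit. The expected step of a number no higher from compound 3 to compound 4 (the limit leaves the size open) is none beyond the scatter. The estimate for compound 4 in this assay is 100000 nM, range 40000 nM to 300000 nM.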

Compound 4, half-maximal cytotoxic concentration: > 100000 nM
Compound 4: only a limit was reported; the forecaster's own chance of this, stated with the estimate: 55%; the middle value lies on the limit itself.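

In this assay compound 4 gives the limit > 100000 nM and no number. Among the compounds shown here, no step from compound 2 or compound 3 to compound 4 can be read: the limit of > 100000 nM in this assay, at which 3 of the 4 values shown sit.

The compounds shown leave open whether compound 2, compound 3 and compound 4 differ at all in this test.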